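The source may report more compounds than this note shows. Statements on the series, on what has been measured and on what is new or still open speak of the compounds shown alone.

Measured so far:
compound 1 `O=C1CS/C(=N\c2csc(-c3ccccc3)c2)N1`, > 50000 nM
compound 2 `CN(C)c1ccc(/C=C2\S/C(=N\c3csc(-c4ccc(Cl)cc4)c3)NC2=O)cc1`, 800 nM

In a functional assay on SW-620 cells (Homo sapiens) for cytotoxicity, read by MTT assay, with a stated time of 72 h (on this read-out higher numbers stand for weaker inhibition and lower numbers for stronger inhibition), compound 1 gives only a limit, > 50000 nM, and not a number. In this assay compound 2 gives 800 nM, the only number shown. The other value, that of compound 1, is the limit of > 50000 nM in this assay, at which 1 of the 2 values shown sits.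

Compound 3 `COc1ccc(/C=C2\S/C(=N\c3csc(-c4ccc(Cl)cc4)c3)NC2=O)cc1OC` carries 3,4-dimethoxyphenyl in place of 4-(dimethylamino)phenyl on a double-bonded chain carbon bound to a double-bonded ring carbon. For the measured compounds named here, no step between measured compounds is known, so the size of this change rests on no precedent. A modest weakening is expected, a 1.9-fold higher number from compound 2 to compound 3 (0.27 log units; within the scatter), rather than a shift beyond the scatter. Compound 3 is therefore estimated at 1500 nM, with a range from 500 nM to 6000 nM.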

Compound 3, half-maximal inhibitory concentration: > 50000 nM
Compound 3: a limit, no number; the forecaster's own chance of this, stated with the estimate: 10%; middle value at least 33-fold (1.52 log units) from the limit.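

This position is sensitive to the group it carries: in this assay, 3,4-dimethoxyphenyl in place of 4-(dimethylamino)phenyl on a double-bonded chain carbon bound to a double-bonded ring carbon gives an at least 62-fold higher number from compound 2 to compound 3 (1.79 log units; beyond the scatter). A six-membered aromatic ring of carbon only at this place is therefore not enough to keep the number of compound 2. Compound 3 gives a limit and not a number, so the full size of the step stays unknown: the limit of > 50000 nM in this assay, at which 2 of the 3 values shown sit.

As far as these compounds go, whether the dimethylamino group itself is required stays open. A 4-methoxyphenyl or a 4-(diethylamino)phenyl at this place would help to separate the contribution of the amine from that of the two methoxy groups.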